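Bromo added to the carbonyl-bearing indole of compound 3

This account rests on a few compounds, and the source may have more. Where it says the series, first, only, none or still open, it means among the compounds named here.

Measured in an ADME assay on A549 cells (Homo sapiens) for cytotoxicity; a higher number here means that more compound is needed for the effect, a lower number that less compound is needed:
- compound 1, `O=C1NC[C@@H](c2c[nH]c3ccccc23)N[C@H]1c1c[nH]c2ccccc12`: > 10 ug/mL, a limit of the assay
- compound 2, `O=C(C1=NC(c2c[nH]c3cc(Br)ccc23)CN1)c1c[nH]c2ccccc12`: 6.82 ug/mL
- compound 3, `O=C(C1=NC(c2c[nH]c3ccccc23)CN1)c1c[nH]c2cc(Br)ccc12`: > 30 ug/mL, a limit of the assay

Compound 3 has no number in this assay, only a limit. Compound 1 likewise sits at a limit in this assay, noted as the limit of > 10 ug/mL in this assay, at which 1 of the 3 values shown sits. The limit of compound 3 is the one recorded as the limit of > 30 ug/mL in this assay, at which 1 of the 3 values shown sits. Going by the values given here, compound 2 is the only member of the set with a measured number in this assay.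

Compound 4, `O=C(C1=NC(c2c[nH]c3cc(Br)ccc23)CN1)c1c[nH]c2cc(Br)ccc12`, is not yet measured. It differs from compound 3 by bromo in place of hydrogen on an aromatic carbon. Among the compounds with values here, no step between two measured compounds covers a change of this kind, so the size of the step is open. Compound 2 carries a bromo group on the other indole and gives a number rather than a limit in this assay, which leaves room for a value below the limit of compound 3.

The expectation for an at least 1.5-fold lower number from compound 3 to compound 4 (0.17 log units; that floor lies within the scatter) is no step beyond the usual scatter, with a downward lean allowed. Compound 4 is estimated at 20 ug/mL in this assay, within 6 ug/mL to 40 ug/mL.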

Compound 4, concentration for half-maximal effect: 5.22 ug/mL
For compound 4 the middle estimate is 3.8-fold (0.58 log units) above the measured one; measured number below the stated range.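

In this assay, the bromo that separates compound 4 from compound 3 sits on the indole that does not bear the carbonyl, and adding it gives an at least 5.7-fold lower number from compound 3 to compound 4 (0.75 log units; beyond the scatter), the first step in the series shown to lie beyond the scatter. Compound 3 holds only a limit, so this step is a floor and not a full size: the limit of > 30 ug/mL in this assay, at which 1 of the 4 values shown sits. The bromo on the carbonyl-bearing indole, added to compound 2, gives a 1.3-fold lower number from compound 2 to compound 4 (0.12 log units; within the scatter), so in this pair the second bromo brings no change beyond the scatter, and the read-out of compound 4 stays in line with that of compound 2, which already carries the bromo on the other indole.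

As far as these compounds go, the true size of the step from compound 3 remains open, as does whether it belongs to bromo itself or would also appear with chloro, methoxy or an amine on the same aromatic carbon. Also open, from the compounds shown here alone, is whether a group other than bromo on the carbonyl-bearing indole, such as a carboxylic acid, would move the number from that of compound 2.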